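A few compounds are considered here, and "the series" means these few. Any claim that something is new, unique, unknown or untested is made for them only; others in the source may bear on it.

Compound 1 `CCCCNc1ccnc2cc(F)ccc12`: 8190 nM
Compound 2 `CN(C)CCNc1ccnc2cc(Cl)ccc12`: > 20000 nM

In a functional assay on 184B5 cells (Homo sapiens) for cytotoxicity, read by sulforhodamine B assay, with a stated time of 48 h, in the presence of a further agent that is not named here (on this read-out lower numbers stand for stronger inhibition of growth and higher numbers for weaker inhibition of growth), compound 1 gives 8190 nM. Compound 2 stands at the limit of > 20000 nM in this assay, at which 1 of the 2 values shown sits, so for compound 2 the result is a limit of the assay, > 20000 nM, and not a number. Compound 3 `CN(C)CCNc1ccnc2cc(F)ccc12` has not yet been measured; it differs from compound 2 by fluoro in place of chloro on an aromatic carbon. Among the compounds with values here, no measured pair shows this change alone, so little shift in this assay is expected, none clearly beyond the usual scatter. Compound 3 is therefore estimated at 20000 nM, with a range from 7000 nM to 60000 nM. The expected change is a number no higher from compound 2 to compound 3 (the limit leaves the size open).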

Compound 3, concentration for 50% growth inhibition: > 20000 nM
Compound 3: no number, only a limit (the forecaster's own chance of this, stated with the estimate: 60%); the middle value sits exactly at the limit.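

In this assay compound 3 gives a limit and not a number, so fluoro in place of chloro on an aromatic carbon is a step that cannot be read. With fluoro kept on the core, the change in the chain can be read: dimethylamino in place of ethyl on a saturated chain carbon gives an at least 2.4-fold higher number from compound 1 to compound 3 (0.38 log units; beyond the scatter). Most of the compounds shown now rest on one limit: the limit of > 20000 nM in this assay, at which 2 of the 3 values shown sit.

On these data alone, whether chloro and fluoro differ at this position remains open. Also open, as far as these compounds go, is whether a hydroxyl group in place of dimethylamino, or bromo in place of fluoro, would give a number.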